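Swapping the hydroxyl position on the second aryl arm

The compounds below may be only part of what the source reports. "The series", "measured", "known", "first", "only" and "open" are said of these compounds alone.

Of the compounds shown here, three sharing one core have been measured in an assay on isolated protein for inhibition of DNA topoisomerase 1 (Homo sapiens), with a stated time of 30 min, tested at 100 uM; on this read-out higher numbers stand for a stronger effect at the one concentration tested and lower numbers for a weaker effect. Compound 3 `Oc1ccc(-c2cc(-c3cccs3)cc(-c3cccc(O)c3)n2)cc1` gives 85.7%, the highest of the three numbers, though compound 1 `Oc1cccc(-c2cc(-c3cccs3)cc(-c3ccccc3O)n2)c1` with 83.2% sits within the scatter of it, and only compound 2 `Oc1ccc(-c2cc(-c3cccs3)cc(-c3ccccc3O)n2)cc1` with 72.2% lies beyond the scatter below it. Compound 4 `Oc1ccc(-c2cc(-c3cccs3)cc(-c3ccc(O)cc3)n2)cc1` has not yet been measured. It differs from compound 3 in one place: 4-hydroxyphenyl in place of 3-hydroxyphenyl on an aromatic carbon.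

The same kind of swap has been seen once already, on the other aryl arm: a number 11 percentage points lower from compound 1 to compound 2 (beyond the scatter). The step of a number 13.5 percentage points higher from compound 2 to compound 3 (beyond the scatter) concerns a different pair of groups and bears only loosely on the question, and a number 2.5 percentage points higher from compound 1 to compound 3 (within the scatter) shows how little the remaining swap mattered there. On this basis a modest drop in this assay is expected for compound 4, of about a number 10.7 percentage points lower from compound 3 to compound 4 (beyond the scatter). The estimate for compound 4 in this assay is therefore 75%, with a range from 62% to 88%.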

Compound 4, a percentage reported as inhibition, at one concentration (the size of the read-out at that concentration, not a potency): 86.3%
For compound 4 the middle estimate is 11.3 percentage points below the measured one; the measured number falls inside the stated range.
By their numbers in this assay, from the lowest: compound 2; then compounds 1, 3 and 4 (each within the scatter of the next).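

In this assay the swap to 4-hydroxyphenyl at this position, next to the ring nitrogen, gives a number 0.6 percentage points higher from compound 3 to compound 4 (within the scatter), so the drop seen with the same swap on the other core did not recur here, although the two steps still agree within their combined scatter: the same change on two cores in this assay, a number 11 percentage points lower (beyond the scatter) from compound 1 to compound 2 and a number 0.6 percentage points higher (within the scatter) from compound 3 to compound 4, 11.6 percentage points apart, within the scatter of two such steps Starting from 2-hydroxyphenyl, the swap to 4-hydroxyphenyl gives a number 14.1 percentage points higher from compound 2 to compound 4 (beyond the scatter), and this larger step also agrees with its counterpart on the other core: the same change on two cores in this assay, a number 2.5 percentage points higher (within the scatter) from compound 1 to compound 3 and a number 14.1 percentage points higher (beyond the scatter) from compound 2 to compound 4, 11.6 percentage points apart, within the scatter of two such steps A 2-hydroxyphenyl arm does not by itself go with the lowest number, since compound 2 gives 72.2% while compound 1, which also carries one, gives 83.2%.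

Every aryl arm shown carries a hydroxyl, so it remains open whether a methoxy group or an amine could stand in its place. These values also show only a stronger or weaker effect at the one concentration tested.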